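Adding a second methoxy group to compound 3

This account rests on a few compounds, and the source may have more. Where it says the series, first, only, none or still open, it means among the compounds named here.

In a functional assay on FM3A cells (Mus musculus) for antiproliferative activity, with a stated time of 48 h (on this read-out lower numbers stand for stronger inhibition and higher numbers for weaker inhibition), compound 1 (`C=C(Br)C(=O)Nc1ccc(C(=O)/C=C/c2cccc(OC)c2)cc1`) gives 1800 nM and compound 2 (`C=C(Br)C(=O)Nc1ccc(C(=O)/C=C/c2ccc(OC)c(OC)c2)cc1`) gives 1200 nM while compound 3 (`COc1cccc(/C=C/C(=O)c2ccc(N)cc2)c1`) gives 45000 nM as the highest number of the three. Compound 4 (`COc1cccc(/C=C/C(=O)c2ccc(N)cc2)c1OC`) differs from compound 3 by a single change: methoxy in place of hydrogen on an aromatic carbon with methoxy in place of hydrogen on an aromatic carbon, ortho to a large group and ortho to a methoxy group.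

The nearest measured precedent is the same kind of replacement, a 1.5-fold lower number from compound 1 to compound 2 (0.18 log units; within the scatter) and so no real change. In compound 2, however, the added methoxy is not ortho to a large group, and the group on the nitrogen differs from that of compound 3. The large step of a 25-fold higher number from compound 1 to compound 3 (1.40 log units; beyond the scatter) concerns that nitrogen group, which compound 4 leaves untouched, so it offers no guide here.

No step beyond the scatter is therefore expected in this assay and the expected step is a 1.3-fold lower number from compound 3 to compound 4 (0.11 log units; within the scatter) in size. Compound 4 is estimated at 35000 nM with an expected range of 14000 nM to 90000 nM in this measurement.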

Compound 4, half-maximal inhibitory concentration: 29000 nM
The estimate for compound 4 lay 1.2-fold (0.08 log units) above the measured number; the measured number falls inside the stated range.
By their numbers in this assay, from the lowest: compounds 2 and 1 (each within the scatter of the next); then compounds 4 and 3 (each within the scatter of the next).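

In this assay, methoxy in place of hydrogen on an aromatic carbon, here ortho to a large group and ortho to a methoxy group, gives a 1.6-fold lower number from compound 3 to compound 4 (0.19 log units; within the scatter). This position therefore takes a methoxy group without a step beyond the scatter, even with hydrogen on the nitrogen, which compound 2 could not show, as its added methoxy is not ortho to a large group. The change reads alike on the two cores: the same change on two cores in this assay, a 1.5-fold lower number (0.18 log units; within the scatter) from compound 1 to compound 2 and a 1.6-fold lower number (0.19 log units; within the scatter) from compound 3 to compound 4, 1.0-fold (0.01 log units) apart, within the scatter of two such steps

From the compounds shown here alone, whether another group at this position, such as an amine, a carboxylic acid or a longer chain, would give a step beyond the scatter stays open. Also open, going by these compounds, is whether this position behaves the same with (1-bromoethenyl)carbonyl on the nitrogen, the group lost in a 25-fold higher number from compound 1 to compound 3 (1.40 log units; beyond the scatter).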